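The compounds below may be only part of what the source reports. "The series", "measured", "known", "first", "only" and "open" are said of these compounds alone.

Compound 3 `O=C(COc1c(-c2ccccc2)oc2ccccc2c1=O)Nc1ccc(F)cc1` carries the 4-fluorophenyl amide on the shared core. In a functional assay on NPC-TW01 cells (Homo sapiens) for antiproliferative activity, read by MTT assay, with a stated time of 72 h (on this read-out higher numbers stand for weaker inhibition of growth and lower numbers for stronger inhibition of growth), compound 3 gives 9500 nM, the highest of the two numbers that came back as numbers; its nearest neighbour is compound 1 `O=C(COc1c(-c2ccccc2)oc2ccccc2c1=O)Nc1ccc2ccccc2c1`, the naphthalen-2-yl analogue, which in this assay gives 6520 nM, the step of a 1.5-fold higher number from compound 1 to compound 3 (0.16 log units; within the scatter) sitting within the scatter. Compound 2 `O=C(COc1c(-c2ccccc2)oc2ccccc2c1=O)Nc1ccccc1` returns in this assay only (the limit of > 10000 nM in this assay, at which 1 of the 3 values shown sits), that is > 10000 nM, a limit and not a number. The step of an at least 1.5-fold higher number from compound 1 to compound 2 (0.18 log units; that floor lies within the scatter) is a floor within the scatter, and the step of an at least 1.0-fold lower number from compound 2 to compound 3 (0.02 log units; that floor lies within the scatter) is likewise a floor within the scatter. All three compounds are therefore weak inhibitors of growth, without a difference between them that the assay resolves.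

Compound 4 `COc1ccc(NC(=O)COc2c(-c3ccccc3)oc3ccccc3c2=O)cc1` differs from compound 3 by methoxy in place of fluoro on an aromatic carbon. The step bearing most directly on this change is the one at the same carbon, an at least 1.0-fold lower number from compound 2 to compound 3 (0.02 log units; that floor lies within the scatter), which showed nothing beyond the scatter, and the two ring exchanges an at least 1.5-fold higher number from compound 1 to compound 2 (0.18 log units; that floor lies within the scatter) and a 1.5-fold higher number from compound 1 to compound 3 (0.16 log units; within the scatter) showed nothing beyond the scatter either. No step beyond the scatter is therefore expected, a 1.1-fold higher number from compound 3 to compound 4 (0.02 log units; within the scatter). Compound 4 is estimated at 10000 nM, with an expected range from 4500 nM to 22000 nM, and a real chance that only a limit is reported.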

Compound 4, concentration for 50% growth inhibition: 5480 nM
For compound 4 the middle estimate is 1.8-fold (0.26 log units) above the measured one; low and high end bracket the measured number.
By their numbers in this assay, from the lowest: compounds 4, 1 and 3 (each within the scatter of the next). At a limit, above all of these: compound 2.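

In this assay, methoxy in place of fluoro on this aromatic carbon gives a 1.7-fold lower number from compound 3 to compound 4 (0.24 log units; within the scatter), so a substituent with one hydrogen-bond acceptor, where fluoro has none, also leaves the number within the scatter. Against the phenyl amide the step is an at least 1.8-fold lower number from compound 2 to compound 4 (0.26 log units; that floor lies within the scatter), and against the naphthalen-2-yl amide it is a 1.2-fold lower number from compound 1 to compound 4 (0.08 log units; within the scatter), so the 4-methoxyphenyl amide is not resolved from either. Compound 2 remains a limit and not a number: the limit of > 10000 nM in this assay, at which 1 of the 4 values shown sits.

Open, from the compounds shown here alone, is whether an amine or a carboxylic acid on this aromatic carbon, or a longer chain in place of methoxy, would give a step beyond the scatter. Also open, going by these compounds, is how far growth inhibition responds to changes on the shared core rather than on the amide nitrogen.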